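A few compounds are considered here, and "the series" means these few. Any claim that something is new, unique, unknown or untested is made for them only; others in the source may bear on it.

Measured so far:
compound 1 `CCCCOc1ccc(C(CC(=O)O)c2ccccc2)cc1` — 1.2 uM
compound 2 `CCCCOc1ccc(C(CC(=O)O)c2ccc(C(F)(F)F)cc2)cc1` — > 10 uM, a limit of the assay

In a functional assay on HEK293 cells for agonist activity at Free fatty acid receptor 1 (Homo sapiens), read by calcium flux (on this read-out higher numbers stand for an effect only at larger amounts of compound and lower numbers for an effect already at smaller amounts), compound 1 gives 1.2 uM, the only number shown in the series. For compound 2 the value > 10 uM is a limit of this assay. The step of an at least 8.3-fold higher number from compound 1 to compound 2 (0.92 log units; beyond the scatter) rests on (the limit of > 10 uM in this assay, at which 1 of the 2 values shown sits).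

Compound 3 `CCCCOc1ccc(C(CC(=O)O)c2ccccc2O)cc1` differs from compound 1 by hydroxy in place of hydrogen on an aromatic carbon. Going by the values given here, the single measured step concerns trifluoromethyl, not hydroxy, so it bears only loosely here. No step beyond the scatter is expected. Compound 3 is expected near 2 uM, within 0.5 uM to 8 uM. The expected step of a 1.7-fold higher number from compound 1 to compound 3 (0.22 log units; within the scatter) is estimated to stay within the scatter.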

Compound 3, concentration for half-maximal effect: 4.8 uM
Beside the measured number, compound 3's estimate is 2.4-fold (0.38 log units) below it, within the range that was stated.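

In this assay, hydroxy ortho to a large group gives a 4.0-fold higher number from compound 1 to compound 3 (0.60 log units; beyond the scatter) and, unlike the earlier change on this ring, ends on a measured number. Compound 2 gives > 10 uM as a limit of the assay, so the sizes of the two changes cannot be set against each other. Nothing measured here accounts for the hydroxy step.

Going by these compounds, whether a methoxy group or an amine at the same place would give a similar step remains open. So does the effect of hydroxy elsewhere on this ring.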